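The compounds below may be only part of what the source reports. "The series", "measured", "known", "first", "only" and "open" are said of these compounds alone.

Measured so far in a functional assay on HepG2 cells (Homo sapiens) for cytotoxicity, read by MTT assay, with a stated time of 72 h; on this read-out higher numbers stand for weaker inhibition and lower numbers for stronger inhibition:
compound 2 `Cc1cc(=O)n(-c2cccc(F)c2)nc1C(=O)Nc1ccc(Oc2ncnc3[nH]ccc23)cc1` gives 3180 nM;
compound 1 `Cn1ccc2c(Oc3ccc(NC(=O)c4nn(-c5ccccc5)ccc4=O)cc3)ccnc21` gives 56200 nM.

Compound 2 holds the lower of the two numbers; compound 1 sits far higher, beyond the scatter, so compound 2 is the stronger inhibitor of the pair.

Compound 3 `Cc1cc(=O)n(-c2cccc(C(F)(F)F)c2)nc1C(=O)Nc1ccc(Oc2ncnc3[nH]ccc23)cc1` differs from compound 2 only by trifluoromethyl in place of fluoro on an aromatic carbon. For the measured compounds named here, no measured pair shows this change, so its effect in this assay is unknown here; the expectation is a step of modest size, possibly toward a lower number, but not clearly beyond the scatter. For compound 3 the expected step is a 1.3-fold lower number from compound 2 to compound 3 (0.10 log units; within the scatter). Compound 3 is estimated at 2500 nM, with a range from 800 nM to 8000 nM.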

Compound 3, half-maximal inhibitory concentration: 9470 nM
For compound 3 the middle estimate is 3.8-fold (0.58 log units) below the measured one, and the stated range ends below it.
By their numbers in this assay, from the lowest: compound 2; then compound 3; then compound 1.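

In this assay, the series now has its first step between compounds that differ in one place: trifluoromethyl in place of fluoro gives a 3.0-fold higher number from compound 2 to compound 3 (0.47 log units; beyond the scatter) at this position on the six-membered aromatic ring. Inhibition in this cell read-out therefore responds to this change, and it is weaker with trifluoromethyl than with fluoro. No measured evidence here accounts for the step.

A single pair leaves open whether the trend extends to other groups at this position, such as methoxy or an amine. It also leaves open whether the same change gives a similar step on the core of compound 1.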